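The source may hold more compounds than are shown below. What is called first, only, known or untested is meant among the compounds shown, and "the series" means these compounds.

Compound 1 `COc1ccccc1NC(=O)Nc1cccc(CNc2nccnc2Cl)c1` carries a 2-methoxyphenyl group on one nitrogen of its shared core; in a functional assay on T-24 cells (Homo sapiens) for antiproliferative activity, read by MTT assay, with a stated time of 48 h (a lower number here means a stronger inhibitor, a higher number a weaker inhibitor), compound 1 gives 10400 nM. Of the two plain numbers shown it stands highest: compound 2 `O=C(Nc1cccc(CNc2nccnc2Cl)c1)Nc1ccc(F)c(Cl)c1` gives 4990 nM, a step of a 2.1-fold lower number from compound 1 to compound 2 (0.32 log units; beyond the scatter). Compound 3 `O=C(Nc1cccc(CNc2nccnc2Cl)c1)NC1CCCC1` reaches only a limit of this assay, > 40000 nM. Compound 4 `O=C(Nc1cccc(CNc2nccnc2Cl)c1)Nc1ccccc1F` differs from compound 1 by fluoro in place of methoxy on an aromatic carbon. Within the data shown here, no measured step exchanges one small group on that ring for another; the closest guide is the exchange of one substituted phenyl for another, a 2.1-fold lower number from compound 1 to compound 2 (0.32 log units; beyond the scatter), which was modest, while an at least 3.8-fold higher number from compound 1 to compound 3 (0.58 log units; beyond the scatter) shows that cyclopentyl in its place weakens the compound. A small step is therefore expected, likely within the scatter. Compound 4 is estimated at 8000 nM, between 3000 nM and 25000 nM. That estimate means a step of a 1.3-fold lower number from compound 1 to compound 4 (0.11 log units; within the scatter).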

Compound 4, half-maximal inhibitory concentration: 7450 nM
Beside the measured number, compound 4's estimate is 1.1-fold (0.03 log units) above it; low and high end bracket the measured number.
By their numbers in this assay, from the lowest: compounds 2, 4 and 1 (each within the scatter of the next, the first and the last beyond it). At a limit, above all of these: compound 3.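

Methoxy and fluoro on this aromatic carbon, ortho to a large group, cannot be told apart here: a 1.4-fold lower number from compound 1 to compound 4 (0.14 log units; within the scatter). Compound 4 also cannot be separated from the 3-chloro-4-fluorophenyl compound, a 1.5-fold higher number from compound 2 to compound 4 (0.17 log units; within the scatter), whereas the 2-fluorophenyl group clearly outperforms cyclopentyl on the same nitrogen, an at least 5.3-fold lower number from compound 3 to compound 4 (0.72 log units; beyond the scatter). Compound 3 gives a limit, not a plain number: the limit of > 40000 nM in this assay, at which 1 of the 4 values shown sits.

As far as these compounds go, whether an amine or a carboxylic acid on this carbon would shift the number remains open. So does what happens with a longer chain in place of methoxy.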